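Moving the bromine on a weakly active hydrazone-thiazole

A few compounds are considered here, and "the series" means these few. Any claim that something is new, unique, unknown or untested is made for them only; others in the source may bear on it.

Two hydrazone-thiazoles have been tested for their effect on the growth of a glioblastoma cell line. In a functional assay on U-87MG ATCC cells for inhibition, with U-87 MG (Homo sapiens) as the target, read by MTT assay, with a stated time of 48 h (on this read-out higher numbers stand for weaker inhibition and lower numbers for stronger inhibition), compound 1 `Fc1ccc(/C=N/Nc2nc(-c3ccc(C(F)(F)F)cc3)cs2)cc1F` gives 29900 nM. In this assay compound 2 `COc1cc(/C=N/Nc2nc(-c3ccc(Br)cc3)cs2)cc(Br)c1OC` gives 27900 nM. The two numbers lie within the usual scatter of each other, so neither compound can be called the stronger of the pair; both sit at a weak level, with concentrations far above what a potent cell-growth inhibitor would show.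

Compound 3 `COc1cc(/C=N/Nc2nc(-c3cccc(Br)c3)cs2)cc(Br)c1OC` keeps every atom of compound 2 and changes only where the bromine sits on the aryl ring attached to the shared core: 3-bromophenyl in place of 4-bromophenyl on an aromatic carbon. Among the measured compounds shown here, there is no measured pair in this set that shows how such a shift of a bromine plays out, so the expectation rests on the weak and closely matched values of compound 1 and compound 2 alone. Compound 3 is expected to stay near that weak level, with a 1.1-fold higher number from compound 2 to compound 3 (0.03 log units; within the scatter) amounting to no step beyond the scatter. In this assay compound 3 is estimated at 30000 nM, within a range from 10000 nM to 90000 nM.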

Compound 3, half-maximal inhibitory concentration: 86300 nM
Compound 3: middle estimate off by 2.9-fold (0.46 log units), on the low side; the range from low to high includes it.
By their numbers in this assay, from the lowest: compounds 2 and 1 (each within the scatter of the next); then compound 3.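

Putting 3-bromophenyl in place of 4-bromophenyl gives a 3.1-fold higher number from compound 2 to compound 3 (0.49 log units; beyond the scatter) in this assay, so this place on the shared core responds to where the bromine sits on the ring, even though the step is modest. Among the compounds shown here, the two groups have the same atoms, which means that the only difference between the compounds is how those atoms are joined, and a higher number here stands for weaker inhibition, so the 4-bromophenyl group is the better of the two in this pair. Nothing at hand explains why the read-out follows the position of the bromine.

The compounds shown leave open whether replacing the bromine on this ring with a different group, such as an amine or a carboxylic acid, would bring the numbers well below the weak level of compound 2 or push them higher still. For the compounds shown here, they also leave open whether the same shift of a substituent would give a similar step with a different group on the other side of the core, such as the one carried by compound 1.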